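A few compounds are considered here, and "the series" means these few. Any claim that something is new, unique, unknown or untested is made for them only; others in the source may bear on it.

The measured compounds:
Compound 1 `O=C(N/N=C/c1cccc(F)c1)c1cccnc1Nc1cccc(C(F)(F)F)c1` gives 52.8% in a functional assay on the whole organism (strain Wistar) for inhibition, with Rattus norvegicus as the target, read by paw edema, with a stated time of 2 h, at a dose of 10 mg/kg by the intraperitoneal route; on this read-out higher numbers stand for more inhibition at the one dose given (going by the name of the read-out) and lower numbers for less inhibition.
Compound 2 `O=C(N/N=C/c1ccc(F)cc1)c1cccnc1Nc1cccc(C(F)(F)F)c1` gives 41.2% in this assay.
Compound 3 `O=C(N/N=C/c1cccc(Cl)c1)c1cccnc1Nc1cccc(C(F)(F)F)c1` gives 63.5% in this assay.

Compound 3 stands highest of the three numbers in this assay: its nearest neighbour is compound 1, with a number 10.7 percentage points higher from compound 1 to compound 3 (beyond the scatter), and the furthest is compound 2, with a number 22.3 percentage points higher from compound 2 to compound 3 (beyond the scatter). The step to compound 4 `O=C(N/N=C/c1ccc(O)cc1)c1cccnc1Nc1cccc(C(F)(F)F)c1` is this: 4-hydroxyphenyl in place of 3-chlorophenyl on a carbon with a double bond to nitrogen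

Among the compounds with values here, two measured steps bear on it. Moving from 3-fluorophenyl to 4-fluorophenyl gave a number 11.6 percentage points lower from compound 1 to compound 2 (beyond the scatter), and swapping chloro for fluoro on the aromatic carbon gave a number 10.7 percentage points higher from compound 1 to compound 3 (beyond the scatter). Within the data shown here, both point the same way: the 4-substituted phenyl and the fluoro rather than chloro each sat on the lower side, and compound 2, the one 4-substituted example, is the lowest of the three. Among the measured compounds shown here, the hydroxy group has no measured counterpart here, so its own contribution in this assay is unknown. On the two steps that are known, a modest downward step is expected, with a number 18.5 percentage points lower from compound 3 to compound 4 (beyond the scatter) taken as the estimate. Compound 4 is therefore expected to give 45% in this assay, within a range from 30% to 60%.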

Compound 4, a percentage reported as inhibition, in the whole organism at one dose (the size of the read-out at that dose, not a potency): 68%
For compound 4 the middle estimate is 23 percentage points below the measured one; the whole stated range lies below it.
By their numbers in this assay, from the lowest: compound 2; then compound 1; then compounds 3 and 4 (each within the scatter of the next).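

In this assay, the 4-hydroxyphenyl group on the carbon with a double bond to nitrogen gives a number 4.5 percentage points higher from compound 3 to compound 4 (within the scatter), so a group at the 4 position of this phenyl ring does not by itself lead to a low number, as compound 2 alone might have suggested. With the substituent kept at the 4 position, hydroxy in place of fluoro gives a number 26.8 percentage points higher from compound 2 to compound 4 (beyond the scatter), the largest step among these compounds, and the change from 3-fluorophenyl to 4-hydroxyphenyl gives a number 15.2 percentage points higher from compound 1 to compound 4 (beyond the scatter), showing that the identity of the substituent counts here as well as where it sits on the ring. Nothing available accounts for this result.

From the compounds shown here alone, it remains open whether the number seen with compound 4 is specific to hydroxy, and a methoxy group or an amine on the same phenyl ring would test that. Going by these compounds, each compound is also known only at a single dose and time, so the order of compounds across a range of doses and the effect of a carboxylic acid at this place remain unknown.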